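Compound 1 loses its fluoro group

A few compounds are considered here, and "the series" means these few. Any claim that something is new, unique, unknown or untested is made for them only; others in the source may bear on it.

Measured in an ADME assay on RAW264.7 cells (Mus musculus) for cytotoxicity, read by MTT assay, with a stated time of 48 h (a higher number here means a weaker inhibitor, a lower number a stronger inhibitor), so far
- compound 1 `CC(C)(Oc1ccc(Cl)cc1)C(=O)NCCOC(=S)Nc1ccc(F)cc1` gives > 800000 nM as a limit
- compound 2 `NC(=S)c1ccc(OC(=O)c2cccnc2)cc1` gives > 800000 nM as a limit
- compound 3 `Cc1cnc(C(=O)OCCCOC(=O)CCCCC2CCSS2)c[n+]1[O-]` gives > 800000 nM as a limit

Compound 1 has no number in this assay and stands only at a limit. The same is true of compound 2 and compound 3, and the whole record reads the limit of > 800000 nM in this assay, at which 3 of the 3 values shown sit, and nothing more.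

Compound 4 `CC(C)(Oc1ccc(Cl)cc1)C(=O)NCCOC(=S)Nc1ccccc1` has not yet been measured. It departs from compound 1 by a single change hydrogen in place of fluoro on an aromatic carbon in which hydrogen takes the place of fluoro on an aromatic carbon, para to a large group. Among the compounds with values here, no measured pair of compounds shows what such a change does.

With compound 1 at > 800000 nM as a limit, the expectation starts from that limit. The expected step of a number no higher from compound 1 to compound 4 (the limit leaves the size open) is none beyond the scatter in this assay and favours neither direction. For compound 4 the estimated value is 800000 nM within an expected range of 400000 nM to 1600000 nM for this reading.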

Compound 4, half-maximal inhibitory concentration: > 800000 nM
Compound 4: no number, only a limit (the forecaster's own chance of this, stated with the estimate: 85%); the middle value sits exactly at the limit.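

In this assay compound 4 gives > 800000 nM, which is a limit and not a number. Within the data shown here, compound 1 also stands only at a limit, and no step from it to compound 4 can be read. The compounds shown leave open whether hydrogen in place of fluoro changes this reading at all, and none of them gives a number: the limit of > 800000 nM in this assay, at which 4 of the 4 values shown sit.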